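Compound 2: 4-chlorophenyl to 4-fluorophenyl

The source may hold more compounds than are shown below. What is called first, only, known or untested is meant among the compounds shown, and "the series" means these compounds.

In a functional assay on HepG2 cells (Homo sapiens) for inhibition, read by MTT assay, with a stated time of 72 h (a lower number here means a stronger inhibitor, a higher number a weaker inhibitor), compound 1 (`CC(C)(C)n1cc2c(n1)C(=O)CC1(CCN(C(=O)c3cc(-c4ccccc4)nc4ccccc34)CC1)O2`) gives 2110 nM on the shared core. Compound 2 (`CC(C)(C)n1cc2c(n1)C(=O)CC1(CCN(C(=O)c3cc(-c4ccc(Cl)cc4)nc4ccccc34)CC1)O2`), with its 4-chlorophenyl, gives 630 nM as the lower of the two numbers in hand. Compound 3 (`CC(C)(C)n1cc2c(n1)C(=O)CC1(CCN(C(=O)c3cc(-c4ccccc4Cl)nc4ccccc34)CC1)O2`), with a 2-chlorophenyl, is held only as a limit (> 10000 nM).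

Compound 4 (`CC(C)(C)n1cc2c(n1)C(=O)CC1(CCN(C(=O)c3cc(-c4ccc(F)cc4)nc4ccccc34)CC1)O2`) is still unmeasured and differs from compound 2 as follows (fluoro in place of chloro on an aromatic carbon): fluoro in place of chloro on an aromatic carbon of a six-membered aromatic ring of carbon only, para to a large group.

The nearest measured change is chloro in place of hydrogen, a modest step (a 3.3-fold lower number from compound 1 to compound 2 (0.52 log units; beyond the scatter)) that gave the 4-chlorophenyl. The two steps to the 2-chlorophenyl (an at least 4.7-fold higher number from compound 1 to compound 3 (0.67 log units; beyond the scatter) and an at least 15-fold higher number from compound 2 to compound 3 (1.20 log units; beyond the scatter)) end at a limit and move the chloro rather than exchange it, so they bear only loosely on this change. For the measured compounds named here, no fluoro compound has been measured in this assay so far.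

Going by the values given here, with a 3.3-fold lower number from compound 1 to compound 2 (0.52 log units; beyond the scatter) as the only guide, part of that step is expected to be undone. The step expected in this assay is a 1.7-fold higher number from compound 2 to compound 4 (0.24 log units; within the scatter) as an estimate. The estimated value for compound 4 is 1100 nM within an expected range from 400 nM to 3000 nM.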

Compound 4, half-maximal inhibitory concentration: 2930 nM
The estimate for compound 4 lay 2.7-fold (0.43 log units) below the measured number; measured number inside the range.
By their numbers in this assay, from the lowest: compound 2; then compounds 1 and 4 (each within the scatter of the next). At a limit, above all of these: compound 3.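

In this assay, the place on the aromatic carbon para to a large group does not treat the two halogens alike: a 4.7-fold higher number from compound 2 to compound 4 (0.67 log units; beyond the scatter) shows that the lower number of compound 2 is lost when fluoro replaces chloro. Set against the parent, a 1.4-fold higher number from compound 1 to compound 4 (0.14 log units; within the scatter) lies within the scatter, so compound 1 and compound 4 cannot be told apart here, and among the groups shown at this place only the chloro of compound 2 separates from hydrogen toward a lower number. The remaining step, an at least 3.4-fold lower number from compound 3 to compound 4 (0.53 log units; beyond the scatter), starts from a value that is a limit, so it gives a bound and not a size, and it also moves the substituent rather than only exchanging it: the limit of > 10000 nM in this assay, at which 1 of the 4 values shown sits.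

The compounds shown hold only hydrogen, fluoro and chloro at this place, which leaves open whether bromo, methyl, methoxy or trifluoromethyl would follow the 4-chlorophenyl or the 4-fluorophenyl. They also give no measured property that could account for the difference between chloro and fluoro, and a single halogen pair cannot establish a trend.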